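The source may report more compounds than this note shows. Statements on the series, on what has been measured and on what is new or still open speak of the compounds shown alone.

Measured in a functional assay on HL-60 cells (Homo sapiens) for antiproliferative activity, read by CCK-8 assay, with a stated time of 72 h; a lower number here means a stronger inhibitor, a higher number a weaker inhibitor:
- compound 1 `Cc1cc(Nc2cc(N3CCN(C)CC3)nc(Nc3ccc(Cl)cc3)n2)n[nH]1`: 83.4 nM
- compound 2 `Cc1cc(Nc2cc(N3CCN(C)CC3)nc(Nc3cccc([N+](=O)[O-])c3)n2)n[nH]1`: 90.9 nM

Compound 2 stands level with compound 1, the two values lying within the scatter of each other. Compound 3 `COc1ccc(Nc2nc(Nc3cc(C)[nH]n3)cc(N3CCN(C)CC3)n2)cc1` is the next exchange at the same place: 4-methoxyphenyl in place of 3-nitrophenyl on a nitrogen on an aromatic ring. Among the measured compounds shown here, one measured step bears on this change, a 1.1-fold higher number from compound 1 to compound 2 (0.04 log units; within the scatter), also an exchange of the group on that nitrogen. On that evidence, no step beyond the scatter is expected in this assay. The step expected is a 1.1-fold higher number from compound 2 to compound 3 (0.04 log units; within the scatter). The estimated value for compound 3 is 100 nM, with an expected range of 40 nM to 250 nM.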

Compound 3, half-maximal inhibitory concentration: 335 nM
Compound 3: the middle estimate sits 3.4-fold (0.53 log units) below what was measured; the measured number lies above the stated range.
By their numbers in this assay, from the lowest: compounds 1 and 2 (each within the scatter of the next); then compound 3.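

In this assay the exchange of 3-nitrophenyl for 4-methoxyphenyl gives a 3.7-fold higher number from compound 2 to compound 3 (0.57 log units; beyond the scatter) and methoxy in place of chloro on an aromatic carbon gives a 4.0-fold higher number from compound 1 to compound 3 (0.60 log units; beyond the scatter) as well. The group on this nitrogen therefore does change the number, although 4-chlorophenyl and 3-nitrophenyl stand level; of the three groups, only 4-methoxyphenyl stands apart. No measurement shown accounts for this step.

Still open, as far as these compounds go, is whether the methoxy group itself or its place on the ring carries the step. Also open, from the compounds shown here alone, is how a phenyl ring bearing an amine or a carboxylic acid would read at this nitrogen.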